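The source may report more compounds than this note shows. Statements on the series, on what has been measured and on what is new or still open speak of the compounds shown alone.

Measured so far in an ADME assay on Huh-7 cells (Homo sapiens) for cytotoxicity, read by MTT assay, with a stated time of 48 h; a higher number here means that more compound is tolerated, a lower number that less compound is tolerated:
- compound 1, `CN(C)CCCCOC(=O)Nc1ccc(Cn2nc(-c3cccc(C#N)c3)c3ccccc3c2=O)cc1`: 17200 nM
- compound 2, `CN(C)CCCCOC(=O)Nc1ccc(Cn2nc(-c3cccc(C(F)(F)F)c3)c3ccccc3c2=O)cc1`: 11600 nM

Compound 2 stands alongside compound 1 here, since a 1.5-fold lower number from compound 1 to compound 2 (0.17 log units; within the scatter). Compound 3, `CN(C)CCCCOC(=O)Nc1ccc(Cn2nc(-c3ccccc3C(F)(F)F)c3ccccc3c2=O)cc1`, differs from compound 2 in one place: 2-(trifluoromethyl)phenyl in place of 3-(trifluoromethyl)phenyl on an aromatic carbon. Going by the values given here, no measured step moves a group around this ring; the only step available swaps one group for another at the same spot, and it stayed within the scatter. Nothing in the data therefore points to a shift beyond the scatter, and the expected step is a 1.0-fold higher number from compound 2 to compound 3 (0.01 log units; within the scatter). For compound 3 in this assay the estimate is 12000 nM, with a range from 5000 nM to 30000 nM.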

Compound 3, half-maximal cytotoxic concentration: 35700 nM
Beside the measured number, compound 3's estimate is 3.0-fold (0.47 log units) below it; the measured number lies above the stated range.
By their numbers in this assay, from the lowest: compounds 2 and 1 (each within the scatter of the next); then compound 3.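

In this assay, the place of the trifluoromethyl group on the phenyl ring changes the result: 2-(trifluoromethyl)phenyl in place of 3-(trifluoromethyl)phenyl gives a 3.1-fold higher number from compound 2 to compound 3 (0.49 log units; beyond the scatter), so more compound is tolerated. Against the 3-cyanophenyl group, the same 2-(trifluoromethyl)phenyl group gives a 2.1-fold higher number from compound 1 to compound 3 (0.32 log units; beyond the scatter), which makes compound 3 the only one here set apart from the others. No measurement shown explains this shift. From the compounds shown here alone, it remains open whether a 2-cyanophenyl or 2-chlorophenyl group would give a similar rise, and how an unsubstituted phenyl would compare.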